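The source may report more compounds than this note shows. Statements on the series, on what has been measured and on what is new or still open speak of the compounds shown alone.

Measured so far in an ADME assay on microsomes from liver (Mus musculus) for metabolic stability, read by LC-MS, using NADPH, with a stated time of 10 min, tested at 0.1 uM; on this read-out lower numbers stand for slow clearance and higher numbers for fast clearance:

compound 1 `COc1ccc(F)cc1N1C(=O)CSC1c1cccc(C(=O)NCCCCn2cccn2)c1` gives 1310 mL.min-1.g-1
compound 2 `COc1ccc(F)cc1N1C(=O)CSC1c1cccc(C(=O)NCCCCc2ccccc2)c1` gives 2250 mL.min-1.g-1
compound 3 `O=C(NCCCCn1cccn1)c1cccc(C2SCC(=O)N2c2ccccn2)c1` gives 304 mL.min-1.g-1

Compound 2 has the highest number of the three, its nearest neighbour being compound 1, which differs from it only on the saturated chain, and the step of a 1.7-fold higher number from compound 1 to compound 2 (0.23 log units; within the scatter) lies within the scatter. The step to compound 3 is wider: a 4.3-fold lower number from compound 1 to compound 3 (0.63 log units; beyond the scatter), a modest change that does lie beyond the scatter.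

The new compound, compound 4 `O=C(NCCCCc1ccccc1)c1cccc(C2SCC(=O)N2c2ccc(C3CC3)cc2)c1`, is reached from compound 2 by the change (4-cyclopropylphenyl in place of 5-fluoro-2-methoxyphenyl on an amide-type nitrogen in a ring).

Among the measured compounds shown here, only the step from compound 1 to compound 3 touches the same place, the amide-type nitrogen in the ring, and there the swap of one aryl group for another moved the number modestly downward. The group entering here is not the one that entered there, so that step sets a rough size rather than a direction. The chain change between compound 1 and compound 2 says nothing about this position.

On this basis compound 4 is expected to stay near the high end seen so far, with an estimated 2000 mL.min-1.g-1, in an expected range from 900 mL.min-1.g-1 to 4500 mL.min-1.g-1. This estimate means an expected step of a 1.1-fold lower number from compound 2 to compound 4 (0.05 log units; within the scatter), not clearly beyond the scatter.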

Compound 4, intrinsic clearance in microsomes: 2960 mL.min-1.g-1
Compound 4: the middle estimate sits 1.5-fold (0.17 log units) below what was measured; low and high end bracket the measured number.
By their numbers in this assay, from the lowest: compound 3; then compounds 1, 2 and 4 (each within the scatter of the next, the first and the last beyond it).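

In this assay, putting 4-cyclopropylphenyl in place of 5-fluoro-2-methoxyphenyl on the amide-type nitrogen in the ring gives a 1.3-fold higher number from compound 2 to compound 4 (0.12 log units; within the scatter) and so leaves the two compounds indistinguishable. This holds even though the entering group has only carbon among its heavy atoms and no hydrogen-bond acceptor, while the leaving group carries oxygen, fluorine and one acceptor. Set against the earlier swap at this position, a 4.3-fold lower number from compound 1 to compound 3 (0.63 log units; beyond the scatter) with pyridin-2-yl entering on a chain ending in 1H-pyrazol-1-yl, this shows that changing the aryl group here does not always move the number beyond the scatter, and the data offer no measured explanation for either outcome.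

Among the compounds shown here, it remains open whether pyridin-2-yl would give a step of similar size on the chain ending in phenyl, since no pair here tests that swap with that chain. On these data alone, it is also open whether a carboxylic acid or an amine such as morpholine, carried on the aryl group at this position, would bring the number down from the high level of compound 2 and compound 4.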